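Replacing the methylphenyl arm of compound 1

The source may hold more compounds than are shown below. What is called first, only, known or untested is meant among the compounds shown, and "the series" means these compounds.

Measured compounds:
compound 1, `Cc1cccc(NC(=O)Nc2cccc(CNc3nccnc3Cl)c2)c1`, 9570 nM in a functional assay on T-24 cells (Homo sapiens) for antiproliferative activity, read by MTT assay, with a stated time of 48 h; a lower number here means a stronger inhibitor, a higher number a weaker inhibitor
compound 2, `O=C(Nc1cccc(CNc2nccnc2Cl)c1)Nc1cccc(C(F)(F)F)c1`, 5080 nM
compound 3, `O=C(Nc1cccc(CNc2nccnc2Cl)c1)Nc1cccc2ccccc12`, > 40000 nM, a limit of the assay

Among the two numbers shown, compound 1 stands highest; its nearest neighbour is compound 2, and the step of a 1.9-fold lower number from compound 1 to compound 2 (0.28 log units; within the scatter) lies within the scatter. Compound 3 gives only a limit, (the limit of > 40000 nM in this assay, at which 1 of the 3 values shown sits).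

Compound 4 is `O=C(Nc1cccc(CNc2nccnc2Cl)c1)Nc1ccc(Cl)cc1Br`. It differs from compound 1 by 2-bromo-4-chlorophenyl in place of 3-methylphenyl on an amide-type nitrogen. Among the compounds with values here, no measured step covers a 2-bromo-4-chlorophenyl group on this nitrogen. Within the data shown here, the one step that changes a substituent on that phenyl ring, a 1.9-fold lower number from compound 1 to compound 2 (0.28 log units; within the scatter), stayed within the scatter, while compound 3, carrying a larger aromatic group there, reached the limit. The account therefore expects compound 4 to show a step of a 1.1-fold lower number from compound 1 to compound 4 (0.03 log units; within the scatter), that is, no change beyond the scatter, with some chance of a weaker result. The estimated value for compound 4 is 9000 nM, within a range from 3000 nM to 30000 nM.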

Compound 4, half-maximal inhibitory concentration: 6650 nM
Compound 4: middle estimate off by 1.4-fold (0.13 log units), on the high side; measured number inside the range.
By their numbers in this assay, from the lowest: compounds 2, 4 and 1 (each within the scatter of the next). At a limit, above all of these: compound 3.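

In this assay, 2-bromo-4-chlorophenyl in place of 3-methylphenyl on the amide-type nitrogen gives a 1.4-fold lower number from compound 1 to compound 4 (0.16 log units; within the scatter). Thus a phenyl ring carrying two halogens at this place, the first such ring in the series, reads no differently from the 3-methylphenyl ring, and compounds 1, 2 and 4 all lie within the scatter of their neighbours in the order of their numbers, so only compound 3, which gives the limit > 40000 nM, stands apart. Nothing shown explains why these phenyl groups read alike.

On these data alone, it remains open whether a ring bearing only the bromine or only the chlorine would read the same. Also open, as far as these compounds go, is whether an amine or a carboxylic acid on this ring, or a cyclohexyl group in its place, would move the number beyond the scatter.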